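Removing the Fluorine from a Sulfonamide Hydroxamic Acid

The source may report more compounds than this note shows. Statements on the series, on what has been measured and on what is new or still open speak of the compounds shown alone.

Compound 1 `O=C(CCCC1CCN(S(=O)(=O)c2ccc(F)cc2)CC1)NO` carries a 4-fluorophenyl sulfonyl cap on the shared core, joined through a piperidine to a hydroxamic acid. In a functional assay on HCT-116 cells (Homo sapiens) for inhibition, read by resazurin assay, with a stated time of 5 days (on this read-out lower numbers stand for stronger inhibition of growth and higher numbers for weaker inhibition of growth), compound 1 is recorded as "not determined" (no result reported), so there is no number on which to place it. For the measured compounds named here, the only measured member of the set is compound 2 `O=C(CCCC1CCN(S(=O)(=O)c2ccc3ccccc3c2)CC1)NO`, which bears a naphthyl in place of the 4-fluorophenyl; in this assay compound 2 gives 1900 nM. The unmeasured partner is compound 3 `O=C(CCCC1CCN(S(=O)(=O)c2ccccc2)CC1)NO`. Against compound 1 it shows (hydrogen in place of fluoro on an aromatic carbon), which, cut one bond further out, reads 4-fluorophenyl to phenyl. Going by the values given here, no pair of measured compounds displays this exchange, and with compound 1 unmeasured no direction can be read from the data; the step from compound 1 to compound 3 in this assay is expected to be small, none beyond the usual scatter. Among the compounds with values here, the single anchor is compound 2 at 1900 nM in this assay. On that basis compound 3 is estimated at 4000 nM in this assay, with an expected range from 1000 nM to 16000 nM.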

Compound 3, concentration for 50% growth inhibition: 2700 nM
The estimate for compound 3 lay 1.5-fold (0.17 log units) above the measured number; low and high end bracket the measured number.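

In this assay, for the compounds shown here, compound 1 has no single number, so no step from it to compound 3 can be read from these results. The compounds shown leave open what exchanging 4-fluorophenyl for phenyl does to growth inhibition in this assay. No further data bear on the value found for compound 3.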